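A few compounds are considered here, and "the series" means these few. Any claim that something is new, unique, unknown or untested is made for them only; others in the source may bear on it.

Measured so far in a functional assay on HEK293 cells for agonist activity at D(4) dopamine receptor (Homo sapiens), read by FLIPR; on this read-out lower numbers stand for an effect already at smaller amounts and higher numbers for an effect only at larger amounts of compound:

- compound 1 `CCc1cccc(NC(=O)CN2CCC(c3cccc[n+]3[O-])CC2)c1` gives 95 nM
- compound 2 `Cc1cccc(C(=O)NCN2CCC(c3nccs3)CC2)c1` gives 9.8 nM
- compound 3 `COc1ccccc1C1CCN(CC(=O)Nc2cccc(C)c2)CC1` gives 420 nM

Among these three numbers, compound 1 stands second highest. Its nearest neighbour is compound 3, whose number is higher by a margin beyond the usual scatter; furthest away is compound 2, whose number is lower by a margin also beyond the scatter. All three compounds share a piperidine-containing core, but they differ in several places at once, so no single change between them can be read off from the numbers.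

Compound 4 `Cc1cc(NC(=O)CN2CCC(c3cccc[n+]3[O-])CC2)ccc1F` has not yet been measured in this assay. It differs from compound 1 in one place: 4-fluoro-3-methylphenyl in place of 3-ethylphenyl on an amide-type nitrogen. The size of the group on the amide-type nitrogen stays the same, and the ring keeps one substituent in the same sense while gaining a fluorine; nothing else about the molecule moves.

Going by the values given here, no measured pair shows this kind of change, so the expectation rests on the change being modest. The step of a 1.2-fold higher number from compound 1 to compound 4 (0.06 log units; within the scatter) is expected to stay within the scatter, in no clear direction. For compound 4 the estimated value is 110 nM, with a range from 40 nM to 300 nM.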

Compound 4, half-maximal effective concentration: 18 nM
Beside the measured number, compound 4's estimate is 6.1-fold (0.79 log units) above it; the measured number lies below the stated range.
By their numbers in this assay, from the lowest: compounds 2 and 4 (each within the scatter of the next); then compound 1; then compound 3.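

The swap from 3-ethylphenyl to 4-fluoro-3-methylphenyl on the amide-type nitrogen gives, in this assay, a 5.3-fold lower number from compound 1 to compound 4 (0.72 log units; beyond the scatter), so an effect is seen at smaller amounts of compound 4. Going by these compounds alone, this is the first one-place step, and it shows that the number responds clearly to the aromatic group at this position, even though the rest of the molecule stays the same. The response also appears without any change in the simple counts: both groups have the same number of heavy atoms, one six-membered aromatic ring of carbon only, no hydrogen-bond donors or acceptors and no net charge, and no measurement here explains the step.

The swap changes two things at once, the ethyl becoming a methyl and a fluorine appearing, so the compounds shown cannot say which one matters or whether both are needed. On the core of compound 1, a 3-methylphenyl group and a 4-fluoro-3-ethylphenyl group would separate these two changes, while 4-chloro-3-methylphenyl would test whether fluorine itself is required.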